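The source may report more compounds than this note shows. Statements on the series, on what has been measured and on what is new or still open speak of the compounds shown alone.

Compound 1, `CC(C)C[C@H](N)c1cc(C(F)(F)F)ccc1N1CCN(C(=O)COc2ccc(O)cc2)CC1`: in an assay on HEK293 cells for displacement of a labelled ligand from Melanocortin receptor 4 (Homo sapiens) (a lower number here means a stronger inhibitor, a higher number a weaker inhibitor), compound 1 gives 4600 nM.
Compound 2, `CC(C)C[C@H](N)c1cc(C(F)(F)F)ccc1N1CCN(C(=O)COc2cccc(Cl)c2Cl)CC1`: compound 2 gives 2500 nM.
Compound 3, `CC(C)C[C@H](N)c1cc(C(F)(F)F)ccc1N1CCN(C(=O)[C@H](C)Cc2ccc(Cl)cc2)CC1`: compound 3 gives 31 nM.

Compound 3 has the lowest number of the three, and its steps to the other compounds are both beyond the scatter: a 150-fold lower number from compound 1 to compound 3 (2.17 log units; beyond the scatter) and an 81-fold lower number from compound 2 to compound 3 (1.91 log units; beyond the scatter). Compound 4, `Cc1ccc(OCC(=O)N2CCN(c3ccc(C(F)(F)F)cc3[C@@H](N)CC(C)C)CC2)c(C)c1`, has not yet been measured. It differs from compound 3 in one place: (2,4-dimethylphenoxy)methyl in place of 1-(4-chlorobenzyl)ethyl on a carbonyl carbon. The two large steps to compound 3 both swapped a phenoxymethyl group for the 1-(4-chlorobenzyl)ethyl group and lowered the number strongly; compound 4 makes the reverse kind of swap, so a large step upward is expected in this assay. Compound 4 is therefore estimated at 2000 nM, with a range of 500 nM to 8000 nM, meaning an expected step of a 65-fold higher number from compound 3 to compound 4 (1.81 log units; beyond the scatter).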

Compound 4, inhibition constant: 4000 nM
Compound 4: the middle estimate sits 2.0-fold (0.30 log units) below what was measured, and the stated range covers the measured number.
By their numbers in this assay, from the lowest: compound 3; then compounds 2, 4 and 1 (each within the scatter of the next).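

On the carbonyl carbon, a third phenoxymethyl-type group now lies far above the 1-(4-chlorobenzyl)ethyl group, with a 130-fold higher number from compound 3 to compound 4 (2.11 log units; beyond the scatter) as the step. Changing the groups on the phenyl ring barely registers, with a 1.6-fold higher number from compound 2 to compound 4 (0.20 log units; within the scatter) and a 1.2-fold lower number from compound 1 to compound 4 (0.06 log units; within the scatter) both small enough that compounds 1, 2 and 4 cannot be told apart. No evidence is available to explain either result.

As far as these compounds go, the large step changes several features at once, so it remains open whether the oxygen, the branching methyl or the chlorine matters most. A (4-chlorophenoxy)methyl group would help separate these.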